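Cytotoxicity of Dithiolethione Esters: From Compound 1 to Compound 4

The compounds below may be only part of what the source reports. "The series", "measured", "known", "first", "only" and "open" are said of these compounds alone.

Measured compounds:
compound 1 `CC(C)Cc1ccc(C(C)C(=O)Oc2ccc(-c3cc(=S)ss3)cc2)cc1`: 889000 nM
compound 2 `O=C(/C=C/c1ccccc1)Oc1ccc(-c2cc(=S)ss2)cc1`: 537000 nM
compound 3 `CC(=O)Nc1ccc(OC(=O)CCCCC2CCSS2)cc1`: 1790000 nM

Three esters carrying a sulfur-rich ring have been tested in an ADME assay on L02 cells (Homo sapiens) for cytotoxicity, read by MTT assay, with a stated time of 24 h; a lower number here means a stronger inhibitor, a higher number a weaker inhibitor. Compound 1 gives 889000 nM, which is the second highest of the three numbers. Its nearest neighbour is compound 2 with 537000 nM, and the furthest is compound 3 with 1790000 nM; both of these gaps lie within the scatter of repeated measurements, so the three compounds cannot be told apart on these data.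

The step in question leads from compound 1 to compound 4 `CC(C(=O)Oc1ccc(-c2cc(=S)ss2)cc1)c1ccc(C(=O)c2ccccc2)cc1`, not yet measured in this assay. The change is benzoyl in place of isobutyl on an aromatic carbon. Going by the values given here, no pair of measured compounds shows a comparable change, so nothing in the set gives a direct guide. Given that compound 1, compound 2 and compound 3 all fall within the scatter of one another despite their different acyl parts, the step is expected to be small, a 1.3-fold lower number from compound 1 to compound 4 (0.10 log units; within the scatter), with no clear direction beyond the scatter. Compound 4 is therefore estimated at 700000 nM, with a plausible range of 250000 nM to 2000000 nM.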

Compound 4, half-maximal inhibitory concentration: 544000 nM
Beside the measured number, compound 4's estimate is 1.3-fold (0.11 log units) above it; the measured number falls inside the stated range.
By their numbers in this assay, from the lowest: compounds 2, 4, 1 and 3 (each within the scatter of the next, the first and the last beyond it).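

In this assay, going by these compounds alone, benzoyl in place of isobutyl on an aromatic carbon, para to a large group, gives a 1.6-fold lower number from compound 1 to compound 4 (0.21 log units; within the scatter) and so provides the first step in the set that can be read at a single place. Although benzoyl brings a six-membered aromatic ring and a hydrogen-bond acceptor that isobutyl lacks, the two compounds cannot be told apart at this position, so this exchange of a larger group for a smaller one has no effect that can be separated from the scatter. No measurement shown offers an explanation for this result.

As far as these compounds go, whether an amine, a carboxylic acid or a longer chain at this same place would move the number beyond the scatter remains open. Also open, from the compounds shown here alone, is whether benzoyl would give a similarly small step on a core other than that of compound 1.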